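Sulfoxide core: chloro to fluoro swap, expected cost

The compounds below may be only part of what the source reports. "The series", "measured", "known", "first", "only" and "open" are said of these compounds alone.

Two cores are compared here, each carrying a halogenated aromatic ring. Compound 2 `COC(=O)C1=C(c2ccc(F)c(Cl)c2)CC2CCC1S2` and compound 1 `COC(=O)C1=C(c2ccc(F)c(F)c2)CC2CCC1S2` share the first core; compound 3 `COC(=O)[C@@H]1C2CCC(C[C@H]1c1ccc(F)c(Cl)c1)[S+]2[O-]` and compound 4 `COC(=O)[C@@H]1C2CCC(C[C@H]1c1ccc(F)c(F)c1)[S+]2[O-]` share the second. How the two cores differ is not broken down here.

In an assay on Caudate-putamen for displacement of a labelled ligand from Transporter (Macaca mulatta) (on this read-out lower numbers stand for stronger inhibition and higher numbers for weaker inhibition), compound 2 gives 7.6 nM. Compound 1 gives 75 nM in this assay. The change between them is fluoro in place of chloro on an aromatic carbon, and it made a step of a 9.9-fold higher number from compound 2 to compound 1 (0.99 log units; beyond the scatter).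

Within the data shown here, compound 3 gives 23 nM in this assay, which puts it between the two measured members of the first core: a lower number than compound 1 and a higher number than compound 2.

Compound 4 is not yet measured. It differs from compound 3 by fluoro in place of chloro on an aromatic carbon, the same change as that from compound 2 to compound 1, at the same place on the ring, ortho to a fluoro group and meta to a large group. Among the measured compounds shown here, only one such pair is measured, so the transfer to the second core rests on a single step.

In this assay the step from compound 3 to compound 4 is expected to be an 8.7-fold higher number from compound 3 to compound 4 (0.94 log units; beyond the scatter), because the same change gave a 9.9-fold higher number from compound 2 to compound 1 (0.99 log units; beyond the scatter), and no sign from the second core argues against a step of that size. Compound 4 is accordingly expected to give 200 nM, with a likely range from 80 nM to 600 nM.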

Compound 4, half-maximal inhibitory concentration: 89 nM
Beside the measured number, compound 4's estimate is 2.2-fold (0.35 log units) above it; measured number inside the range.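

In this assay, fluoro in place of chloro on an aromatic carbon again weakens inhibition on the second core, giving a 3.9-fold higher number from compound 3 to compound 4 (0.59 log units; beyond the scatter) and matching the first core in direction. Set side by side, the two steps cannot be told apart in size, so the smaller number on the second core is no evidence of a smaller penalty there: the same change on two cores in this assay, a 9.9-fold higher number (0.99 log units; beyond the scatter) from compound 2 to compound 1 and a 3.9-fold higher number (0.59 log units; beyond the scatter) from compound 3 to compound 4, 2.6-fold (0.41 log units) apart, within the scatter of two such steps. This supports carrying the change between these two cores as a rise of similar size, but it rests on two pairs with a single swap at one place on the ring, so it shows neither a fixed step size on any further core nor why chloro is preferred.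

The compounds shown leave open how other groups would rank against chloro and fluoro at this place, ortho to a fluoro group, such as bromo, methyl or trifluoromethyl. They also leave open whether the step keeps its direction and size when the methyl ester gives way to a longer chain ester or an amide.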